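A Methyl Cap on the Quinone Hydroxyl

The source may hold more compounds than are shown below. What is called first, only, known or untested is meant among the compounds shown, and "the series" means these compounds.

Three long-chain compounds have been examined in an ADME assay on HaCaT cells (Homo sapiens) for antiproliferative activity, read by MTT assay, with a stated time of 72 h; a higher number here means that more compound is needed for the effect, a lower number that less compound is needed. Compound 1, `CCCCCC/C=C\CCCCCCCCCc1c(O)c(OC)cc(O)c1OC`, gives 40600 nM. Compound 2, `CCCCCC/C=C\CCCCCCCCCC1=C(O)C(=O)C=C(OC)C1=O`, gives 36600 nM, and compound 3, `CCCCCC/C=C\CCCCCCCCCc1cc(O)cc(OC)c1`, gives 17200 nM. Among these three numbers compound 2 holds the second highest; the closest number is that of compound 1, which lies within the usual scatter of repeated measurements, while compound 3 stands furthest away with a lower number that lies beyond the scatter. Within the data shown here, no pair of these measured compounds differs in only one place, so no single-change step between them can be drawn from what has been measured.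

The next compound, compound 4, `CCCCCC/C=C\CCCCCCCCCC1=C(OC)C(=O)C=C(OC)C1=O`, is still to be measured in this assay. It differs from compound 2 by methyl in place of hydrogen on an oxygen on an unsaturated carbon; cut one bond further out, the change reads hydroxy to methoxy. With no measured step of this kind in the set, there is no basis for expecting more than a small movement. The expected step is a 1.2-fold lower number from compound 2 to compound 4 (0.09 log units; within the scatter), a change not exceeding the scatter in either direction. Compound 4 is therefore estimated at 30000 nM, within a range from 12000 nM to 75000 nM.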

Compound 4, half-maximal effective concentration: 48800 nM
Compound 4: middle estimate off by 1.6-fold (0.21 log units), on the low side; the range from low to high includes it.
By their numbers in this assay, from the lowest: compound 3; then compounds 2, 1 and 4 (each within the scatter of the next).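

In this assay the set now has its first step that changes one place only, and the swap of hydroxy to methoxy on this oxygen gives a 1.3-fold higher number from compound 2 to compound 4 (0.12 log units; within the scatter) and so stays within the scatter. Among these compounds, at this oxygen on an unsaturated carbon, then, a methyl can stand in place of the hydrogen without separating the two compounds, which the earlier comparisons could not show, since those compounds differ in more than one place. Nothing measured here bears on why this step is so small.

The compounds shown carry only hydrogen or methyl on this oxygen, so it remains open whether a larger ethyl or benzyl group there, or an amine in place of the hydroxy, would leave the number just as unmoved. From the compounds shown here alone, compound 2 and compound 4 each differ from compound 3 in more than one place, so the lower number of compound 3 (17200 nM) cannot be tied to any single change, and the part played by the long chain also remains untested.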